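Ring Size on the Thiocarbonyl: Pyrrolidine to Piperidine

The source may hold more compounds than are shown below. What is called first, only, known or untested is meant among the compounds shown, and "the series" means these compounds.

Measured so far in a functional assay on HeLa cells (Homo sapiens) for antiproliferative activity, read by MTT assay, with a stated time of 72 h; on this read-out higher numbers stand for weaker inhibition and lower numbers for stronger inhibition:
compound 1 `O=c1c(SC(=S)N2CCCCC2)coc2ccccc12` gives 9000 nM
compound 2 `O=c1cc(CSC(=S)N2CCCCC2)oc2cc(Cl)ccc12` gives a limit, > 25000 nM
compound 3 `O=c1cc(CSC(=S)N2CCCC2)oc2ccccc12` gives 23100 nM

Compound 3 holds the highest of the two numbers actually reported, and its nearest neighbour is compound 1, whose number is lower by a gap beyond the usual scatter. For compound 2 the assay reports only a limit, (the limit of > 25000 nM in this assay, at which 1 of the 3 values shown sits), and not a number.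

Compound 4 `O=c1cc(CSC(=S)N2CCCCC2)oc2ccccc12` has not yet been measured. It differs from compound 3 in one place: piperidin-1-yl in place of pyrrolidin-1-yl on a thiocarbonyl carbon. Within the data shown here, the same piperidin-1-yl group is present in compound 1 and compound 2, but both differ from compound 4 elsewhere as well, so no single step isolates this change. Given the weak numbers around it, compound 4 is expected to stay in the same weak region, with the step from compound 3 estimated as a 1.2-fold lower number from compound 3 to compound 4 (0.06 log units; within the scatter), within the scatter. Compound 4 is estimated at 20000 nM, in the range 8000 nM to 50000 nM.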

Compound 4, half-maximal inhibitory concentration: > 25000 nM
Compound 4: only a limit was reported; the forecaster's own chance of this, stated with the estimate: 35%; middle value at least 1.2-fold (0.09 log units) from the limit.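

In this assay, piperidin-1-yl in place of pyrrolidin-1-yl on a thiocarbonyl carbon gives an at least 1.0-fold higher number from compound 3 to compound 4 (0.03 log units; that floor lies within the scatter). As far as these compounds go, the true size of this step is unknown, but the larger ring shows no gain in inhibition over the smaller one on the shared core. Compound 4 is reported only as a limit, and the step from compound 2 to compound 4, hydrogen in place of chloro on an aromatic carbon, cannot be read, because both compounds sit at the same limit: the limit of > 25000 nM in this assay, at which 2 of the 4 values shown sit.

From the compounds shown here alone, it remains open whether any other group on the thiocarbonyl carbon, such as morpholin-4-yl or an open-chain diethylamino group, would give a clearly lower number than compound 3 on this core. Going by these compounds, the real potency of compound 4 also remains unknown.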